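This account rests on a few compounds, and the source may have more. Where it says the series, first, only, none or still open, it means among the compounds named here.

Among the compounds with values here, in a functional assay on HepG2 cells (Homo sapiens) for cytotoxicity, with a stated time of 24 h (on this read-out lower numbers stand for stronger inhibition and higher numbers for weaker inhibition), compound 1 `COc1ccc(Cl)cc1C(=S)Nc1ccc(Cl)cc1O` gives 4450 nM, and compound 2 `COc1ccc(Cl)cc1C(=S)Nc1cc(Cl)c(Cl)cc1O`, the only other compound measured so far, gives 3720 nM; these two numbers lie within the scatter of each other. Compound 3 `COc1ccc(Cl)cc1C(=S)Nc1ccc(Br)cc1O` has not yet been measured. It carries bromo in place of chloro on an aromatic carbon. Within the data shown here, the only measured step, chloro in place of hydrogen on an aromatic carbon, is a 1.2-fold lower number from compound 1 to compound 2 (0.08 log units; within the scatter). It is a different change and so only a rough guide, but it gives no reason to expect a shift beyond the scatter in this assay. The expected step is a 1.1-fold lower number from compound 1 to compound 3 (0.03 log units; within the scatter). For compound 3 the estimated value is 4200 nM, with an expected range of 2200 nM to 8000 nM.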

Compound 3, half-maximal inhibitory concentration: 7600 nM
For compound 3 the middle estimate is 1.8-fold (0.26 log units) below the measured one; low and high end bracket the measured number.
By their numbers in this assay, from the lowest: compounds 2, 1 and 3 (each within the scatter of the next, the first and the last beyond it).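

Putting bromo in place of chloro on this carbon, para to a large group, gives a 1.7-fold higher number from compound 1 to compound 3 (0.23 log units; within the scatter) in this assay. The earlier step added a chloro elsewhere on the ring, whereas this one exchanges the halogen at this place, and the exchange gives no difference that can be told from the scatter. Nothing available here bears on the size of this step. Still open, as far as these compounds go, is how an amine or a carboxylic acid at this place would read in this assay, and whether such a group would move the number beyond the scatter.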